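This account rests on a few compounds, and the source may have more. Where it says the series, first, only, none or still open, it means among the compounds named here.

Measured compounds:
compound 1 `CC(C)(C)C1=CC(=O)C=C(NCC(=O)O)C1=O` – in a functional assay on A549 cells (Homo sapiens) for cytotoxicity, read by MTT assay, with a stated time of 72 h (on this read-out higher numbers stand for weaker inhibition and lower numbers for stronger inhibition), compound 1 gives > 200000 nM
compound 2 `CC1=CCC[C@H]2[C@](C)(CC3=CC(=O)C=C(N[C@@H](CC(C)C)C(=O)O)C3=O)[C@@H](C)CC[C@]12C` – compound 2 gives 19700 nM
compound 3 `CC1=CCC[C@H]2[C@](C)(CC3=CC(=O)C=C(NCC(=O)O)C3=O)[C@@H](C)CC[C@]12C` – compound 3 gives 46700 nM.

For compound 1 the reported value is a limit of the assay, not a measured number (the limit of > 200000 nM in this assay, at which 1 of the 3 values shown sits). Compound 3 and compound 2 share one core and differ in a single place: isobutyl in place of hydrogen on a saturated chain carbon bound to an amine nitrogen and a carbonyl carbon. This change gave a 2.4-fold lower number from compound 3 to compound 2 (0.37 log units; beyond the scatter).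

Compound 4 `CC(C)C[C@H](NC1=CC(=O)C=C(C(C)(C)C)C1=O)C(=O)O` has not been measured yet. It is built from compound 1 by the same kind of change: isobutyl in place of hydrogen on a saturated chain carbon bound to an amine nitrogen and a carbonyl carbon. The difference between the core of compound 1 and the core of compound 3 is not broken down here.

From compound 1 to compound 4, a step of roughly the size seen from compound 3 to compound 2 is expected, resting on a 2.4-fold lower number from compound 3 to compound 2 (0.37 log units; beyond the scatter), so the expectation is an at least 1.3-fold lower number from compound 1 to compound 4 (0.12 log units; that floor lies within the scatter). Because compound 1 sits at a limit (the limit of > 200000 nM in this assay, at which 1 of the 3 values shown sits), the measured outcome for compound 4 may again be only a limit. The estimate for compound 4 is 150000 nM, with a likely range from 50000 nM to 600000 nM.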

Compound 4, half-maximal inhibitory concentration: 97900 nM
Estimate against measurement, compound 4: 1.5-fold (0.19 log units) above; low and high end bracket the measured number.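

In this assay, isobutyl in place of hydrogen on the saturated chain carbon bound to an amine nitrogen and a carbonyl carbon gave an at least 2.0-fold lower number from compound 1 to compound 4 (0.31 log units; beyond the scatter), so the number falls on both cores, and the change carries over in direction: the same change on two cores in this assay, a 2.4-fold lower number (0.37 log units; beyond the scatter) from compound 3 to compound 2 and an at least 2.0-fold lower number (0.31 log units; beyond the scatter) from compound 1 to compound 4; the limit leaves it open whether they differ

Compound 1 gives > 200000 nM, which is a limit of the assay and not a measured number, so this step has a floor but no known full size. The data therefore do not show that the change has the same size on both cores, and two cores are too few to make it a rule for the whole series.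

As far as these compounds go, it remains open whether a different group on the same carbon, such as methyl, benzyl or a longer chain ending in an amine, would lower the number as well. From the compounds shown here alone, it is also open whether the same result would hold on further cores, with a different group in place of the tert-butyl of compound 1.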